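Adding a Nitrile to Compound 1: an Expected Value

The source may report more compounds than this note shows. Statements on the series, on what has been measured and on what is new or still open speak of the compounds shown alone.

Compound 1 `C(=C/c1nc2ncccc2[nH]1)\c1ccccc1`: 3870 nM
Compound 2 `Clc1ccccc1/C=C/c1nc2ncccc2[nH]1`: > 100000 nM, a limit of the assay
Compound 3 `Clc1cccnc1/C=C/c1nc2ncccc2[nH]1`: > 100000 nM, a limit of the assay

Going by the values given here, in an ADME assay on WI-38 cells (Homo sapiens) for antiproliferative activity, read by MTT assay, with a stated time of 72 h (a higher number here means a weaker inhibitor, a lower number a stronger inhibitor), compound 1 is the only compound of the three that gives a number; the other two values are limits. Compound 2 differs from compound 1 by chloro in place of hydrogen on an aromatic carbon, and the step of an at least 25-fold higher number from compound 1 to compound 2 (1.41 log units; beyond the scatter) is large. Among the compounds with values here, compound 3 reaches a limit in this assay as well, and no single-point step links it to compound 1. The the limit of > 100000 nM in this assay, at which 2 of the 3 values shown sit, is where both of these compounds sit.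

Compound 4 `N#Cc1ccc(/C=C/c2nc3ncccc3[nH]2)cc1` differs from compound 1 by cyano in place of hydrogen on an aromatic carbon. Within the data shown here, the only measured step from compound 1, the one to compound 2, is a large weakening, but it concerns a different group at a different place, so it gives only a loose guide. Against this background compound 4 is expected to land somewhat weaker than compound 1, with the step of a 2.3-fold higher number from compound 1 to compound 4 (0.37 log units; beyond the scatter) carrying wide uncertainty. Compound 4 is therefore estimated at 9000 nM in this assay, within a range of 2000 nM to 60000 nM.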

Compound 4, half-maximal inhibitory concentration: > 100000 nM
Compound 4: no number, only a limit; the forecaster's own chance of this, stated with the estimate: 25%; middle value at least 11-fold (1.04 log units) from the limit.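

The new step, an at least 25-fold higher number from compound 1 to compound 4 (1.41 log units; beyond the scatter), shows that a large change in this assay is not confined to the chloro group of compound 2: a cyano group also produces one when it sits on an aromatic carbon of a six-membered aromatic ring of carbon only, para to a large group. That step ends at a limit of the assay, and so does an at least 25-fold higher number from compound 1 to compound 2 (1.41 log units; beyond the scatter); the two cannot be ranked against each other, and neither gives the full size of its change. Compound 1 remains the only compound of the four with a number, and the others give no gradation among themselves: the limit of > 100000 nM in this assay, at which 3 of the 4 values shown sit.

The compounds shown leave open whether a methyl group, a methoxy group, an amine or a carboxylic acid at this same position would keep a number close to that of compound 1, or would also reach the limit. They also leave open whether any group in place of hydrogen on this ring can give a stronger value than compound 1.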